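This account rests on a few compounds, and the source may have more. Where it says the series, first, only, none or still open, it means among the compounds named here.

Measured so far:
Compound 1 `C[N+]1(C)C[C@@H]2C[C@H]1CN2c1ccc(-c2ccccc2)nn1`: 700 nM
Compound 2 `C[N+]1(C)C[C@@H]2C[C@H]1CN2c1ccc(Cl)nn1`: 4.3 nM
Compound 3 `Clc1ccc(N2C[C@@H]3C[C@H]2CN3)nn1`: 6 nM

These values come from an assay on brain for displacement of a labelled ligand from Neuronal acetylcholine receptor; alpha4/beta2 (Rattus norvegicus); on this read-out higher numbers stand for weaker inhibition and lower numbers for stronger inhibition. The step of a 160-fold higher number from compound 2 to compound 1 (2.21 log units; beyond the scatter) is the large step here, made by phenyl in place of chloro on an aromatic carbon. Compound 4 `c1ccc(-c2ccc(N3C[C@@H]4C[C@H]3CN4)nn2)cc1` carries the same kind of change on the core of compound 3, (phenyl in place of chloro on an aromatic carbon); the place differs only in being para to a group of 7 heavy atoms rather than 9 heavy atoms, and the difference between the two cores is not broken down here. Compound 3 and compound 2 stand within the usual scatter of each other. On that footing, compound 4 is expected to move by about a 130-fold higher number from compound 3 to compound 4 (2.12 log units; beyond the scatter), resting on a 160-fold higher number from compound 2 to compound 1 (2.21 log units; beyond the scatter) as the one measured case of this change. The estimate for compound 4 in this assay is 800 nM, between 200 nM and 4000 nM.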

Compound 4, inhibition constant: 31200 nM
The estimate for compound 4 lay 39-fold (1.59 log units) below the measured number; the whole stated range lies below it.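

In this assay phenyl in place of chloro gives a 5200-fold higher number from compound 3 to compound 4 (3.72 log units; beyond the scatter) on the core of compound 3. The number rises on both cores, but the size of the step does not carry over from one core to the other: the same change on two cores in this assay, a 160-fold higher number (2.21 log units; beyond the scatter) from compound 2 to compound 1 and a 5200-fold higher number (3.72 log units; beyond the scatter) from compound 3 to compound 4, 32-fold (1.50 log units) apart, beyond the scatter of two such steps. This shows that one measured step on one core gave the direction of this change here but not a dependable size, and it does not show why the two cores differ.

Only chloro and phenyl are shown at this place, so how a methyl group or an amine there would behave on either core stays open. Going by these compounds, whether other replacements would also differ this much between the two cores also stays open.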